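Three Inactive Amides and a Fourth Benzyl Group

The source may report more compounds than this note shows. Statements on the series, on what has been measured and on what is new or still open speak of the compounds shown alone.

In an assay on isolated protein for inhibition of thyroid hormone receptor beta (Homo sapiens), read by fluorescence polarization (a lower number here means a stronger inhibitor, a higher number a weaker inhibitor), the three measured compounds read as follows:

Compound 1 `CS(=O)(=O)c1ccc(C(=O)N2CCC(C(=O)N(Cc3ccccc3)c3ccccc3)CC2)cc1[N+](=O)[O-]`: > 60000 nM
Compound 2 `CN(Cc1ccccc1)C(=O)C1CCN(C(=O)c2ccc(S(C)(=O)=O)c([N+](=O)[O-])c2)CC1`: > 60000 nM
Compound 3 `CC1Cc2ccccc2N1C(=O)C1CCN(C(=O)c2ccc(S(C)(=O)=O)c([N+](=O)[O-])c2)CC1`: > 60000 nM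

Each of these values is a limit of the assay, not a number; none of the three compounds produced a measurable inhibition. Compound 2 therefore stands only at a limit, and so do the two other values shown. The step from compound 1 to compound 2 is a step that the two limits leave unreadable from compound 1 to compound 2, and the step from compound 2 to compound 3 is a step that the two limits leave unreadable from compound 2 to compound 3; neither can be read in size, because of the limit of > 60000 nM in this assay, at which 3 of the 3 values shown sit.

Compound 4 `CS(=O)(=O)c1ccc(C(=O)N2CCC(C(=O)N(Cc3ccccc3)Cc3ccccc3)CC2)cc1[N+](=O)[O-]` differs from compound 2 by one change: phenyl in place of hydrogen on a saturated chain carbon bound to an amide-type nitrogen. Both measured steps bear on this change, since each alters the same amide-type nitrogen region and each ends at the same limit. Going by the values given here, nothing among the measured compounds points to a gain in potency from the new phenyl group. The expected step from compound 2 to compound 4 is therefore a step that the limit leaves unreadable from compound 2 to compound 4, meaning no movement beyond the scatter. Compound 4 is expected to give 80000 nM in this assay, with a range from 20000 nM to 300000 nM, most likely again reported as a limit.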

Compound 4, half-maximal inhibitory concentration: > 60000 nM
Compound 4: only a limit was reported; the forecaster's own chance of this, stated with the estimate: 85%; the middle value lies beyond the limit too.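

Compound 4 gives > 60000 nM in this assay, which is a limit of the assay and not a number. No new step can be read between compound 4 and compound 1 or compound 2, because all the values share one limit: the limit of > 60000 nM in this assay, at which 4 of the 4 values shown sit.

The compounds shown leave open whether any change on the amide-type nitrogen can give measurable inhibition.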